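The compounds below may be only part of what the source reports. "The series", "measured", "known", "first", "only" and "open" are said of these compounds alone.

Measured so far in a toxicity assay on NIH3T3 cells (Mus musculus) for cytotoxicity, read by resazurin assay; a lower number here means that less compound is needed, a higher number that more compound is needed for the effect:
compound 1 `COC(=O)c1ccc(NCc2cncn2Cc2ccccc2N)cc1-c1ccccc1`: 25000 nM
compound 2 `c1ccc(-c2ccc(Cn3cncc3CNc3ccc(-c4ccc[nH]4)c(-c4ccccc4)c3)cc2)cc1`: > 10000 nM, a limit of the assay rather than a number
compound 3 `COC(=O)c1ccc(NCc2cncn2Cc2ccc(OC)cc2)cc1-c1ccccc1`: "not determined" (no result reported)

Compound 3 stands without a number in this assay. Of the values that exist in the set, one is a plain number, from compound 1, and one sits at a limit, as shown by the limit of > 10000 nM in this assay, at which 1 of the 3 values shown sits. Compound 2 returned only that limit. Going by the values given here, no two measured compounds differ in a single place, so no step within the measured set can be read, and no direction for the series can be taken from a pair.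

The change from compound 3 to compound 4 `COC(=O)c1ccc(NCc2cncn2Cc2ccc(-c3ccccc3)cc2)cc1-c1ccccc1` is phenyl in place of methoxy on an aromatic carbon. Compound 3 carries no value, so this change has no starting number; whatever is expected of compound 4 rests on compound 1 and compound 2 alone, both of which fall at high concentration in this assay. No step beyond the usual scatter is expected from this change in either direction. The estimated value for compound 4 in this assay is 20000 nM, with a range from 7000 nM to 60000 nM. A further limit rather than a number remains a real possibility for compound 4.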

Compound 4, half-maximal effective concentration: > 1000 nM
Compound 4 was reported as a limit; the forecaster's own chance of this, stated with the estimate: 40%; the middle value lies beyond the limit too.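

In this assay compound 4 gives > 1000 nM, a limit of the assay and not a number. No new step can be read between compound 4 and either compound 1 or compound 2. The compounds shown leave open how 4-phenylphenyl in compound 4 compares with 4-methoxyphenyl in compound 3 in this assay.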